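Halogen swap on the aryl-oxadiazole: bromo to chloro

The compounds below may be only part of what the source reports. "The series", "measured", "known", "first", "only" and "open" are said of these compounds alone.

The series shares one core, shown in compound 2 `COc1ccc(Cl)cc1-n1ncc(-c2nnc(-c3ccc(Br)cc3)o2)c1C`. In a physicochemical assay for lipophilicity, using the shake flask method, measured as octanol-water partition (on this read-out lower numbers stand for lower lipophilicity and higher numbers for higher lipophilicity), compound 2 gives 4.88. Compound 1 `COc1ccc(Cl)cc1-n1ncc(-c2nnc(-c3ccc(C)c([N+](=O)[O-])c3)o2)c1C` gives 6.42, and compound 3 `COc1ccc(Cl)cc1-n1ncc(-c2nnc(-c3ccc(F)cc3)o2)c1C` gives 4.26. Compound 2 therefore stands second highest of the three numbers, with compound 3 its nearest neighbour and compound 1 the furthest.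

Compound 4 `COc1ccc(Cl)cc1-n1ncc(-c2nnc(-c3ccc(Cl)cc3)o2)c1C` has not yet been run in this assay. Against compound 2 the change is chloro in place of bromo on an aromatic carbon.

Of the measured steps only one bears directly on this change: a number 0.62 log units lower from compound 2 to compound 3 (beyond the scatter), where fluoro in place of bromo on the same aromatic carbon gave a modest drop. The steps of a number 1.54 log units lower from compound 1 to compound 2 (beyond the scatter) and a number 2.16 log units lower from compound 1 to compound 3 (beyond the scatter) involve the nitro-bearing aryl group and say nothing about a halogen-for-halogen exchange. Chloro lies between bromo and fluoro in this assay's usual ordering of halogens, so the change is expected to run in the same downward direction as the step to compound 3, only smaller and close to the scatter. The expected step is estimated as a number 0.20 log units lower from compound 2 to compound 4 (within the scatter). For compound 4 the expected value in this assay is 4.68, with a range from 4.38 to 4.98.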

Compound 4, partition coefficient: 4.51
Estimate against measurement, compound 4: 0.17 log units above; the range from low to high includes it.
By their numbers in this assay, from the lowest: compounds 3 and 4 (each within the scatter of the next); then compound 2; then compound 1.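

Bromo and chloro can be told apart at this aromatic carbon, para to a large group: in this assay, the exchange gives a modest drop (a number 0.37 log units lower from compound 2 to compound 4 (beyond the scatter)), while chloro and fluoro cannot be separated (a number 0.25 log units higher from compound 3 to compound 4 (within the scatter)). With the earlier step from bromo to fluoro (a number 0.62 log units lower from compound 2 to compound 3 (beyond the scatter)), the three halogen compounds therefore fall into two groups, with compound 2 on its own and compounds 3 and 4 together, so this set gives no graded halogen series. The 4-chlorophenyl compound also stays far from the 4-methyl-3-nitrophenyl compound (a number 1.91 log units lower from compound 1 to compound 4 (beyond the scatter)), so the large gap seen with the 4-bromophenyl and 4-fluorophenyl compounds holds for a third halogen, and nothing shown here accounts for any of these steps.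

Open at this carbon is how iodo, methyl, trifluoromethyl, an amine or a carboxylic acid would read in place of the halogen, and whether compound 1's distance comes from its methyl group, its nitro group or the two together. On these data alone, the chloro and methoxy groups elsewhere on the shared core are the same in all four compounds, so whether the bromo-to-chloro step would carry over to another site also stays open.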